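The source may hold more compounds than are shown below. What is called first, only, known or untested is meant among the compounds shown, and "the series" means these compounds.

The compounds measured so far:
compound 1 `COc1cccc(/C=C/c2ccc(F)cc2)c1OC` gives 2900 nM in an assay on HepG2 cells for activation of nuclear factor erythroid 2-related factor 2 (Homo sapiens), read by a luciferase reporter, with a stated time of 5 h; on this read-out lower numbers stand for an effect already at smaller amounts and higher numbers for an effect only at larger amounts of compound;
compound 2 `COc1cccc(/C=C/c2ccccc2)c1OC` gives 4700 nM in this assay;
compound 3 `COc1cccc(/C=C/c2ccc(C)cc2)c1OC` gives 1100 nM in this assay.

Compound 3 gives the lowest of the three numbers in this assay: the step of a 2.6-fold lower number from compound 1 to compound 3 (0.42 log units; beyond the scatter) and the step of a 4.3-fold lower number from compound 2 to compound 3 (0.63 log units; beyond the scatter) both lie beyond the scatter, so compound 3 stands apart from the other two, whereas the step of a 1.6-fold higher number from compound 1 to compound 2 (0.21 log units; within the scatter) lies within it. Compound 4 `COc1cccc(/C=C/c2ccc(C(F)(F)F)cc2)c1OC` has not yet been measured. The change from compound 3 to compound 4 is trifluoromethyl in place of methyl on an aromatic carbon. For the measured compounds named here, none of the measured steps involves a trifluoromethyl group. Going by the values given here, the steps that bear on this place are a 4.3-fold lower number from compound 2 to compound 3 (0.63 log units; beyond the scatter) and a 2.6-fold lower number from compound 1 to compound 3 (0.42 log units; beyond the scatter), which show that the methyl-bearing compound 3 gives the lowest number, and a 1.6-fold higher number from compound 1 to compound 2 (0.21 log units; within the scatter), which lies within the scatter. Among the compounds with values here, the data therefore show what methyl, fluoro and hydrogen give at this place but offer no precedent for trifluoromethyl, so the estimate carries a wide range. For compound 4 the expected step in this assay is a 1.4-fold higher number from compound 3 to compound 4 (0.13 log units; within the scatter). Compound 4 is estimated to give 1500 nM in this assay, with a range from 500 nM to 5000 nM.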

Compound 4, half-maximal effective concentration: 2200 nM
Estimate against measurement, compound 4: 1.5-fold (0.17 log units) below, and the stated range covers the measured number.
By their numbers in this assay, from the lowest: compounds 3, 4, 1 and 2 (each within the scatter of the next, the first and the last beyond it).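

In this assay, trifluoromethyl on an aromatic carbon para to a large group cannot be told apart from methyl, since the step in question is a 2.0-fold higher number from compound 3 to compound 4 (0.30 log units; within the scatter) and so lies within the usual scatter. Compared with the unsubstituted ring, the same group gives a 2.1-fold lower number from compound 2 to compound 4 (0.33 log units; beyond the scatter) and thus becomes the second group in this short series, after methyl, to stand clear of hydrogen at this place, though only modestly, while the comparison with fluoro gives a 1.3-fold lower number from compound 1 to compound 4 (0.12 log units; within the scatter) and separates the two groups no more than the scatter allows. Compound 4 therefore sits within the scatter of both compound 3 and compound 1, although those two lie beyond the scatter of each other, so the four groups do not fall into two clean sets, and nothing given here accounts for how they fall.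

As far as these compounds go, whether an amine, a carboxylic acid, a methoxy group or a longer chain at this place would stay close to methyl and trifluoromethyl remains open. So does whether the differences seen here would hold if the two methoxy groups on the other ring of the shared core were changed.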